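This account rests on a few compounds, and the source may have more. Where it says the series, first, only, none or still open, it means among the compounds named here.

Of the compounds shown here, three sharing one core have been tested in a functional assay on C6 cells (Rattus norvegicus) for cytotoxicity, read by MTT assay, with a stated time of 24 h, tested at 25 ug/mL; on this read-out higher numbers stand for a weaker effect at the one concentration tested and lower numbers for a stronger effect. Compound 1 `Cc1ccc(-c2cs/c(=N/NC(=O)CSc3nnnn3-c3ccccc3)n2-c2ccccc2)cc1` gives 38.8%. Compound 2 `O=C(CSc1nnnn1-c1ccccc1)N/N=c1/scc(-c2ccc(Cl)cc2)n1-c1ccccc1` gives 62.3%. Compound 3 `O=C(CSc1ncccn1)N/N=c1/scc(-c2ccc(Cl)cc2)n1-c1ccccc1` gives 91.1%, the highest of the three numbers and so the weakest effect on the cells. Compound 2 and compound 3 differ only in the group attached to the sulfur: pyrimidin-2-yl in place of 1-phenyl-1H-tetrazol-5-yl on a sulfur. That exchange produced a step of a number 28.8 percentage points higher from compound 2 to compound 3 (beyond the scatter). Compound 1 and compound 2 differ in a single substituent: methyl in place of chloro on an aromatic carbon. That exchange produced a step of a number 23.5 percentage points lower from compound 2 to compound 1 (beyond the scatter).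

Compound 4 `Cc1ccc(-c2cs/c(=N/NC(=O)CSc3ncccn3)n2-c2ccccc2)cc1` has not yet been measured. It stands to compound 3 exactly as compound 1 stands to compound 2: methyl in place of chloro on an aromatic carbon. The two descriptions of the place agree word for word, so this is the same change, made on the core of compound 3 instead of the core of compound 2; the two cores differ in the group on the sulfur, as already told.

Going by the values given here, only one measured example of this change exists, so the expectation rests on a single step. From compound 3 to compound 4 the step is estimated at a number 21.1 percentage points lower from compound 3 to compound 4 (beyond the scatter), about the size of the earlier a number 23.5 percentage points lower from compound 2 to compound 1 (beyond the scatter). Compound 4 is therefore expected to give 70%, with the likely range running from 50% to 92%.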

Compound 4, a percentage reported as activity, at one concentration (the size of the read-out at that concentration, not a potency): 82.7%
For compound 4 the middle estimate is 12.7 percentage points below the measured one, within the range that was stated.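

Swapping 4-chlorophenyl for 4-methylphenyl does not carry over at the same size from one core to the other in this assay. With pyrimidin-2-yl on the sulfur the step is a number 8.4 percentage points lower from compound 3 to compound 4 (within the scatter), which is smaller than the step seen with 1-phenyl-1H-tetrazol-5-yl on the sulfur: the same change on two cores in this assay, a number 23.5 percentage points lower (beyond the scatter) from compound 2 to compound 1 and a number 8.4 percentage points lower (within the scatter) from compound 3 to compound 4, 15.1 percentage points apart, beyond the scatter of two such steps

Read the other way round, the exchange of the group on the sulfur, made on the methyl-bearing core, is a number 43.9 percentage points higher from compound 1 to compound 4 (beyond the scatter), and this also differs from the same exchange made on the chloro-bearing core: the same change on two cores in this assay, a number 28.8 percentage points higher (beyond the scatter) from compound 2 to compound 3 and a number 43.9 percentage points higher (beyond the scatter) from compound 1 to compound 4, 15.1 percentage points apart, beyond the scatter of two such steps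

These four compounds form a single square, so the two comparisons are one observation seen from two sides; it shows that the two changes do not simply add up here, but it does not show why, or whether this would hold for any other pair of groups.

Still open, as far as these compounds go, is whether a fluoro or a methoxy in the same place on the aromatic ring would follow the chloro or the methyl result on either core. Also open is how a different group on the sulfur, such as a plain phenyl or a 1-methyl-1H-tetrazol-5-yl, would fit, and how any of these compounds would behave at concentrations other than the one tested.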